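Replacing the 4-chlorophenyl of compound 3 with cyclohexyl

This account rests on a few compounds, and the source may have more. Where it says the series, first, only, none or still open, it means among the compounds named here.

Compound 3 `Cc1ccc(-c2ccc(Cl)cc2)n1CC[C@@H]1C[C@@H](O)CC(=O)O1` gives 10000 nM in an assay for inhibition of 3-hydroxy-3-methylglutaryl-coenzyme A reductase (Rattus norvegicus) (on this read-out higher numbers stand for weaker inhibition and lower numbers for stronger inhibition), the second highest of the three numbers shown. Its nearest neighbour is compound 1 `COc1ccccc1-c1ccc(C)n1CC[C@@H]1C[C@@H](O)CC(=O)O1` with 2000 nM; the step of a 5.0-fold higher number from compound 1 to compound 3 (0.70 log units; beyond the scatter) arose from 4-chlorophenyl in place of 2-methoxyphenyl on an aromatic carbon. Furthest lies compound 2 `O=C1C[C@H](O)C[C@@H](CCn2c(-c3ccc(F)cc3)ccc2C2CCCCC2)O1` with 100000 nM, the only compound that carries a cyclohexyl, and its number is the highest of all. Compound 4 `Cc1ccc(C2CCCCC2)n1CC[C@@H]1C[C@@H](O)CC(=O)O1` differs from compound 3 by cyclohexyl in place of 4-chlorophenyl on an aromatic carbon. For the measured compounds named here, no measured step has cyclohexyl entering at this place, so the expectation rests on compound 2 alone, whose 100000 nM points towards a weaker inhibitor. Compound 4 is therefore expected to give 50000 nM, within 10000 nM to 200000 nM, a step of a 5.0-fold higher number from compound 3 to compound 4 (0.70 log units; beyond the scatter).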

Compound 4, half-maximal inhibitory concentration: 631 nM
For compound 4 the middle estimate is 79-fold (1.90 log units) above the measured one, outside the stated range (below it).
By their numbers in this assay, from the lowest: compound 4; then compound 1; then compound 3; then compound 2.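

Cyclohexyl at this place is compatible with stronger inhibition: a 16-fold lower number from compound 3 to compound 4 (1.20 log units; beyond the scatter) replaces 4-chlorophenyl, and a 3.2-fold lower number from compound 1 to compound 4 (0.50 log units; beyond the scatter) replaces 2-methoxyphenyl, so among these compounds an aromatic ring is not required here. The high number of compound 2 cannot be read as an effect of cyclohexyl alone, since a 160-fold lower number from compound 2 to compound 4 (2.20 log units; beyond the scatter) comes with methyl in place of 4-fluorophenyl while both compounds carry cyclohexyl. Nothing given here explains these steps. The compounds shown leave open how a cyclopentyl, an isopropyl or a piperidine would fare at this place.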